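The source may report more compounds than this note shows. Statements on the series, on what has been measured and on what is new or still open speak of the compounds shown alone.

In a functional assay on HCT-116 cells (Homo sapiens) for antiproliferative activity, read by MTT assay, with a stated time of 72 h (on this read-out higher numbers stand for weaker inhibition and lower numbers for stronger inhibition), compound 3 `O=C1COc2ccc(-c3cccc(NS(=O)(=O)c4ccc(F)cc4)c3)cc2N1c1ccccc1` gives > 40000 nM, which is a limit and not a number. Compound 1 `COc1cccc(N2C(=O)COc3ccc(-c4cccc(NS(=O)(=O)c5ccc(F)cc5)c4)cc32)c1` gives > 40000 nM, again a limit. Within the data shown here, compound 2 `CC(C)N1C(=O)COc2ccc(-c3cccc(NS(=O)(=O)c4ccc(F)cc4)c3)cc21` gives 22600 nM, the only true number so far.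

Compound 4 `COc1ccc(N2C(=O)COc3ccc(-c4cccc(NS(=O)(=O)c5ccc(F)cc5)c4)cc32)cc1` differs from compound 3 in one place: methoxy in place of hydrogen on an aromatic carbon. In words, methoxy stands in place of hydrogen on an aromatic carbon, turning phenyl into 4-methoxyphenyl.

Compound 1 also carries a methoxy on that ring, placed differently, so it is the closest guide. Taking its methoxy away gives a step that the two limits leave unreadable from compound 1 to compound 3. Changing the group on the amide-type nitrogen gives an at least 1.7-fold lower number from compound 1 to compound 2 (0.24 log units; that floor lies within the scatter) and then an at least 1.7-fold higher number from compound 2 to compound 3 (0.24 log units; that floor lies within the scatter). None of these shows a change beyond the scatter, so no step beyond the scatter is expected here in this assay.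

The expected change is a number no higher from compound 3 to compound 4 (the limit leaves the size open). Compound 4 is expected to read about 40000 nM, with an estimated range from 18000 nM to 80000 nM.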

Compound 4, half-maximal inhibitory concentration: 28300 nM
Compound 4: middle estimate off by 1.4-fold (0.15 log units), on the high side; measured number inside the range.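

In this assay, the 4-methoxyphenyl group on the amide-type nitrogen gives a true number where phenyl and 3-methoxyphenyl give only limits, with an at least 1.4-fold lower number from compound 3 to compound 4 (0.15 log units; that floor lies within the scatter) and an at least 1.4-fold lower number from compound 1 to compound 4 (0.15 log units; that floor lies within the scatter). Set against isopropyl on the same nitrogen, there is a 1.3-fold higher number from compound 2 to compound 4 (0.10 log units; within the scatter), so these two cannot be told apart on this read-out. The first two steps remain floors, with their true sizes unknown, because their starting values are limits and not numbers: the limit of > 40000 nM in this assay, at which 2 of the 4 values shown sit.

As far as these compounds go, whether any group on this nitrogen can move the number beyond the scatter stays open. From the compounds shown here alone, how an amine or a carboxylic acid on that phenyl ring, or a longer chain in place of isopropyl, would read also remains unknown.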